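Swapping an Amide for a Saturated Ring

The compounds below may be only part of what the source reports. "The series", "measured", "known", "first", "only" and "open" are said of these compounds alone.

Measured so far, in an assay on isolated protein for inhibition of Polyunsaturated fatty acid 5-lipoxygenase (Homo sapiens); a higher number here means a weaker inhibitor, a lower number a stronger inhibitor:
- compound 1, `CCCCNc1cc(Cl)nc(SC(C(=O)O)c2cccc3ccccc23)n1`, gives 2400 nM
- compound 2, `O=C(O)C(Sc1nc(Cl)cc(Nc2ccc(F)cc2)n1)c1cccc2ccccc12`, gives 3100 nM
- compound 3, `O=C(Nc1ccc(Nc2cc(Cl)nc(SC(C(=O)O)c3cccc4ccccc34)n2)cc1)c1ccccc1`, gives 600 nM

All three share the same core; they differ only in what hangs on the nitrogen attached to the ring. Compound 3 gives the lowest number of the three, and both gaps to it lie beyond the scatter, so on these numbers it is the strongest inhibitor. The step of a 1.3-fold higher number from compound 1 to compound 2 (0.11 log units; within the scatter) stays within the scatter, whereas a 5.2-fold lower number from compound 2 to compound 3 (0.71 log units; beyond the scatter) is a modest gain.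

Compound 4, `O=C(O)C(Sc1nc(Cl)cc(Nc2ccc(C3CCCCC3)cc2)n1)c1cccc2ccccc12`, keeps everything of compound 3 except one change: cyclohexyl in place of benzamido on an aromatic carbon. Within the data shown here, the only measured step that touches this position is the one from compound 2 to compound 3, where the benzamido group brought a modest gain. Among the measured compounds shown here, compound 4 removes that very group and puts a cyclohexyl in its place, for which no measured step exists. The expectation is therefore that some of the gain is given back, while the cyclohexyl may still leave compound 4 somewhere between compound 2 and compound 3. Compound 4 is estimated at 1500 nM in this assay, with a range of 500 nM to 4000 nM, which is expected to be a step of a 2.5-fold higher number from compound 3 to compound 4 (0.40 log units; beyond the scatter).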

Compound 4, half-maximal inhibitory concentration: 400 nM
For compound 4 the middle estimate is 3.8-fold (0.57 log units) above the measured one; the measured number lies below the stated range.
By their numbers in this assay, from the lowest: compounds 4 and 3 (each within the scatter of the next); then compounds 1 and 2 (each within the scatter of the next).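

In this assay the change from benzamido to cyclohexyl gives a 1.5-fold lower number from compound 3 to compound 4 (0.18 log units; within the scatter), so a group of quite different make-up serves as well at this aromatic carbon. Cyclohexyl has fewer heavy atoms than benzamido, no aromatic ring, no hydrogen-bond donor and no hydrogen-bond acceptor, yet the change from fluoro to cyclohexyl gives a 7.8-fold lower number from compound 2 to compound 4 (0.89 log units; beyond the scatter), so the amide of benzamido is not required for a number well under that of the fluoro compound. Nothing measured here explains why two such different groups give numbers this close.

The compounds shown leave open whether a ring is needed at this place at all, a question that a hexyl chain or a smaller cyclopropyl ring on the same aromatic carbon would help to settle. They also leave open what happens when nitrogen or oxygen returns to this position, as it would with a morpholine ring or a carboxylic acid.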